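The source may report more compounds than this note shows. Statements on the series, on what has been measured and on what is new or still open speak of the compounds shown alone.

Compound 2, with the structure `O=C(NC(=O)c1ccc(OCc2ccccc2F)cc1)Nc1ccc(Cl)c(-c2nc3ccccc3[nH]2)c1`, is the lower of the two numbers obtained so far in a functional assay on SW-620 cells (Homo sapiens) for inhibition, read by MTT assay, with a stated time of 48 h; on this read-out lower numbers stand for stronger inhibition and higher numbers for weaker inhibition: in this assay compound 2 gives 2930 nM. Going by the values given here, the other measured compound, compound 1 with the structure `Cc1ccc(COc2ccc(C(=O)NC(=O)Nc3ccc(C)c(-c4nc5ccccc5[nH]4)c3)cc2)cc1`, gives 26000 nM in this assay, a gap that lies beyond the usual scatter; the two compounds differ in more than one place, so no single step between them can be read off.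

Compound 3, with the structure `Cc1ccc(COc2ccc(C(=O)NC(=O)Nc3ccc(Cl)c(-c4nc5ccccc5[nH]4)c3)cc2)cc1`, differs from compound 2 in one place only: 4-methylphenyl in place of 2-fluorophenyl on a saturated chain carbon bound to an oxygen on an aromatic ring. The same group that enters here is already present in compound 1, whose weaker number in this assay is the only hint available. Taken together with the number of compound 2, the step from compound 2 to compound 3 is expected to go towards weaker inhibition by a moderate amount, a 2.7-fold higher number from compound 2 to compound 3 (0.44 log units; beyond the scatter), though a change within the scatter cannot be ruled out. On this basis compound 3 is expected to give about 8000 nM in this assay, with a plausible range from 2000 nM to 30000 nM.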

Compound 3, half-maximal inhibitory concentration: 23200 nM
Compound 3: middle estimate off by 2.9-fold (0.46 log units), on the low side; the measured number falls inside the stated range.
By their numbers in this assay, from the lowest: compound 2; then compounds 3 and 1 (each within the scatter of the next).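

In this assay, going by these compounds alone, the exchange of 2-fluorophenyl for 4-methylphenyl on a saturated chain carbon bound to an oxygen on an aromatic ring gives a 7.9-fold higher number from compound 2 to compound 3 (0.90 log units; beyond the scatter), the first single change at this position that can be read, and it shows that the group placed here matters in this assay. The other new step, chloro in place of methyl on an aromatic carbon, gives a 1.1-fold lower number from compound 1 to compound 3 (0.05 log units; within the scatter), so with 4-methylphenyl present this exchange does not separate the two compounds, and the gap between compounds 1 and 2 that could not be divided before now rests almost wholly on the change at the chain carbon. Nothing available gives a reason for either step.

Still open, from the compounds shown here alone, is whether the fluoro group, the methyl group or the ring place each occupies sets the difference; a plain phenyl, a 4-fluorophenyl or a 2-methylphenyl would be needed to tell these apart. Also open, going by these compounds, is whether chloro and methyl stay this close when 2-fluorophenyl is the group on the chain carbon.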